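From allyl to phenyl: notes on compound 3

The compounds below may be only part of what the source reports. "The series", "measured", "known", "first", "only" and "open" are said of these compounds alone.

In a functional assay (brain) with Rattus norvegicus as the target (a higher number here means a weaker inhibitor, a lower number a stronger inhibitor), compound 1 `C=Cc1ccc([C@H]2CCN(C)C[C@H]2C(=O)OC)cc1` gives 144 nM as a measured number. Compound 2 `C=CCc1ccc([C@H]2CCN(C)C[C@H]2C(=O)OC)cc1` gives > 1000 nM in this assay and this is a limit of the assay, not a number.

Compound 3 `COC(=O)[C@@H]1CN(C)CC[C@@H]1c1ccc(-c2ccccc2)cc1` has phenyl in place of allyl on an aromatic carbon, para to a large group, a change counted as phenyl in place of allyl on an aromatic carbon for this pair. Within the data shown here, the one measured step that bears on it has allyl in place of vinyl on an aromatic carbon. Among the measured compounds shown here, compound 3 is expected to remain a weak inhibitor because an at least 6.9-fold higher number from compound 1 to compound 2 (0.84 log units; beyond the scatter) is the only measured change of this group, and it lies beyond the scatter toward the higher number. For the measured compounds named here, that step ends at a limit, so it gives a direction but no size, and no measured step involves phenyl. No step beyond the scatter is therefore expected. The estimated step is a step that the limit leaves unreadable from compound 2 to compound 3 in this reading. For compound 3 the expected value is 1500 nM in this assay, with an estimated range from 300 nM to 6000 nM around it.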

Compound 3, half-maximal inhibitory concentration: 184 nM
Compound 3: middle estimate off by 8.2-fold (0.91 log units), on the high side, outside the stated range (below it).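

In this assay, the aromatic carbon para to a large group accepts phenyl as well as vinyl: phenyl in place of vinyl gives a 1.3-fold higher number from compound 1 to compound 3 (0.11 log units; within the scatter). The number of heavy atoms alone does not follow the values in this short series, as phenyl carries 6 heavy atoms against 3 for allyl, and the change from allyl to phenyl gives an at least 5.4-fold lower number from compound 2 to compound 3 (0.73 log units; beyond the scatter). That step starts from a limit of the assay and not a number, so it gives a direction but no size: the limit of > 1000 nM in this assay, at which 1 of the 3 values shown sits.

On these data alone, whether the level shared by the vinyl and phenyl compounds extends to a phenyl ring carrying a methoxy group or an amine, or to a saturated ring such as cyclohexyl, remains open. Also open is whether a saturated chain such as propyl, or a longer chain, stands with allyl, and the three compounds shown cannot separate the part played by the double bond from that of the chain.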